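The source may hold more compounds than are shown below. What is called first, only, known or untested is meant among the compounds shown, and "the series" means these compounds.

Measured so far:
- compound 1, `CCCC(C)C(=O)Nc1c(C(O)(C(F)(F)F)C(F)(F)F)ccc2ccccc12`: in an assay on LtK cells with ATP-sensitive inward rectifier potassium channel 11 (Homo sapiens) as the target (a higher number here means that more compound is needed for the effect, a lower number that less compound is needed), compound 1 gives > 10000 nM, which is a limit of the assay and not a number.
- compound 2, `O=C(Nc1c(C(O)(C(F)(F)F)C(F)(F)F)ccc2ccccc12)C1CCCC1`: in this assay compound 2 gives 495 nM.
- compound 3, `O=C(NCCCCCCCl)Nc1c(C(O)(C(F)(F)F)C(F)(F)F)ccc2ccccc12`: in this assay compound 3 gives 4840 nM.

Compound 3 therefore has the highest of the two real numbers shown; compound 2 sits below it, with a 9.8-fold higher number from compound 2 to compound 3 (0.99 log units; beyond the scatter) separating them. All three compounds share the same core and differ only in the group attached to the carbonyl carbon.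

Compound 4 is `O=C(Nc1c(C(O)(C(F)(F)F)C(F)(F)F)ccc2ccccc12)c1ccc(Br)cc1`. The change from compound 3 to compound 4 is 4-bromophenyl in place of (6-chlorohexyl)amino on a carbonyl carbon. For the measured compounds named here, two measured steps touch this position. Replacing the cyclopentyl group of compound 2 with the (6-chlorohexyl)amino group raised the number, a 9.8-fold higher number from compound 2 to compound 3 (0.99 log units; beyond the scatter), while moving from the 1-methylbutyl group of compound 1 to the same (6-chlorohexyl)amino group lowered it, an at least 2.0-fold lower number from compound 1 to compound 3 (0.31 log units; beyond the scatter). Going by the values given here, no measured compound carries an aromatic ring at this position, so the direction for compound 4 rests only on the observation that a ring-bearing group in compound 2 gave the lowest number seen. Compound 4 is therefore expected to move toward lower numbers, with a step of about a 4.0-fold lower number from compound 3 to compound 4 (0.61 log units; beyond the scatter), though with wide uncertainty. The estimate for compound 4 in this assay is 1200 nM, expected to lie between 250 nM and 6000 nM.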

Compound 4, half-maximal effective concentration: 47 nM
Beside the measured number, compound 4's estimate is 26-fold (1.41 log units) above it, outside the stated range (below it).
By their numbers in this assay, from the lowest: compound 4; then compound 2; then compound 3. At a limit, above all of these: compound 1.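

For the compounds shown here, on this carbonyl carbon, 4-bromophenyl gives a 100-fold lower number from compound 3 to compound 4 (2.01 log units; beyond the scatter) and an 11-fold lower number from compound 2 to compound 4 (1.02 log units; beyond the scatter), so the only group here with an aromatic ring gives the lowest number of the four compounds in this assay. Among these compounds, the order now runs from the aromatic ring through the saturated cyclopentyl ring of compound 2 to the open chains of compound 3 and compound 1, and the comparison with the open chain of compound 1 shows an at least 210-fold lower number from compound 1 to compound 4 (2.32 log units; beyond the scatter). Compound 1 stands at a limit of the assay and not at a number, so that last step gives only a bound: the limit of > 10000 nM in this assay, at which 1 of the 4 values shown sits.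

The compounds shown do not separate the contribution of the aromatic ring from that of its bromine, which an unsubstituted phenyl group or a 4-methoxyphenyl group at this place could begin to do. Going by these compounds, it also remains open whether a ring containing nitrogen, such as pyridyl, or bromine at another place on the ring would keep a number this low.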